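Removing one chloro from the dichlorophenyl ring: compound 4

The source may report more compounds than this note shows. Statements on the series, on what has been measured and on what is new or still open speak of the compounds shown alone.

Measured so far:
compound 1 `C=CCn1c(=O)/c(=C\c2cccc(Cl)c2)[nH]c(=O)/c1=C\c1ccccc1OC` gives 2700 nM in a functional assay on K562 cells (Homo sapiens) for cytotoxicity, read by CCK-8 assay, with a stated time of 72 h; a lower number here means a stronger inhibitor, a higher number a weaker inhibitor
compound 2 `C=CCn1c(=O)/c(=C\c2cccc(Cl)c2Cl)[nH]c(=O)/c1=C\c1ccccc1OC` gives 900 nM in this assay
compound 3 `COc1ccccc1/C=c1\c(=O)[nH]/c(=C/c2cccc(Cl)c2Cl)c(=O)n1C` gives 110 nM in this assay

Compound 4 `COc1ccccc1/C=c1\c(=O)[nH]/c(=C/c2ccccc2Cl)c(=O)n1C` has not yet been measured. It differs from compound 3 by hydrogen in place of chloro on an aromatic carbon. The same kind of change was already made between two measured compounds: compound 1 differs from compound 2 by hydrogen in place of chloro on an aromatic carbon, and that step read a 3.0-fold higher number from compound 2 to compound 1 (0.48 log units; beyond the scatter). The surroundings of the place are not identical, though: in the measured pair the carbon is ortho to a large group, while in compound 4 it is meta to a large group. The two cores also differ, by hydrogen in place of vinyl on a saturated chain carbon bound to an aromatic nitrogen, a change that on its own gave an 8.2-fold lower number from compound 2 to compound 3 (0.91 log units; beyond the scatter), so compound 3 stands as the lowest of the three measured numbers.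

For compound 4 the expectation rests on compound 3 with 110 nM and on the earlier step of a 3.0-fold higher number from compound 2 to compound 1 (0.48 log units; beyond the scatter): a step of about a 3.0-fold higher number from compound 3 to compound 4 (0.48 log units; beyond the scatter) is expected. Compound 4 is therefore estimated at 330 nM, most likely between 150 nM and 750 nM.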

Compound 4, half-maximal inhibitory concentration: 110 nM
Estimate against measurement, compound 4: 3.0-fold (0.48 log units) above; measured number outside the range, below it.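

Going from the 2,3-dichlorophenyl group to the 2-chlorophenyl group on the core of compound 3 gives no change at the digits printed from compound 3 to compound 4 (within the scatter) in this assay, so here the chloro that leaves can go without the number moving. Replacing a chloro with hydrogen therefore did not carry the same result from one core to the other: the same change on two cores in this assay, a 3.0-fold higher number (0.48 log units; beyond the scatter) from compound 2 to compound 1 and no change at the digits printed (within the scatter) from compound 3 to compound 4, 3.0-fold (0.48 log units) apart, beyond the scatter of two such steps. This does not show that the core alone sets the outcome, since the chloro lost is not at the same place on the ring in the two pairs, so core and place change together, and each case rests on a single pair of compounds.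

The compounds shown leave open what the 2-chlorophenyl group does on the core of compound 2, and what the 3-chlorophenyl group does on the core of compound 3, the two comparisons that would pull core and place apart. Also open, going by these compounds, is how a fluoro, a methoxy or a nitrile would read in place of the remaining chloro of compound 4.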